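This account rests on a few compounds, and the source may have more. Where it says the series, first, only, none or still open, it means among the compounds named here.

Measured so far:
compound 1 `O=C(COc1ccc2c(=O)cc(-c3ccccc3)oc2c1)Nc1ccc2ccccc2c1`: > 10000 nM
compound 2 `O=C(COc1ccc2oc(-c3ccccc3)cc(=O)c2c1)Nc1ccc(-c2ccccc2)cc1`: 640 nM

In a functional assay on NPC-TW01 cells (Homo sapiens) for antiproliferative activity, read by MTT assay, with a stated time of 72 h (a higher number here means a weaker inhibitor of growth, a lower number a stronger inhibitor of growth), compound 1 gives only a limit, > 10000 nM, which is not a number but the edge of what the measurement reports (the limit of > 10000 nM in this assay, at which 1 of the 2 values shown sits). In this assay compound 2 gives 640 nM; compound 1 and compound 2 differ in more than one place, so the gap between them is not assigned to any single change and is noted only as what the two values show.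

Compound 3 `O=C(COc1ccc2c(=O)cc(-c3ccccc3)oc2c1)Nc1ccc(F)cc1` keeps the core of compound 1 and carries the change (4-fluorophenyl in place of naphthalen-2-yl on an amide-type nitrogen). Among the measured compounds shown here, no measured pair shows this exchange, so the size of the step rests on expectation alone. Since compound 1 stands at the limit of this assay, a step in the direction of stronger growth inhibition is expected, with no confidence that it brings compound 3 into the measurable range. The step from compound 1 to compound 3 is estimated as an at least 1.6-fold lower number from compound 1 to compound 3 (0.22 log units; that floor lies within the scatter). For compound 3 the expected value in this assay is 6000 nM, with a range from 1500 nM to 20000 nM.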

Compound 3, concentration for 50% growth inhibition: > 10000 nM
Compound 3: a limit, no number; the forecaster's own chance of this, stated with the estimate: 40%; middle value at least 1.6-fold (0.22 log units) away from the limit.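

In this assay compound 3 gives > 10000 nM, which is a limit and not a number. Compound 1 and compound 3 both stand at that limit, so no step can be read between them: the limit of > 10000 nM in this assay, at which 2 of the 3 values shown sit.

The compounds shown leave open how far 4-fluorophenyl and naphthalen-2-yl on an amide-type nitrogen differ in growth inhibition on the core of compound 1.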